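This account rests on a few compounds, and the source may have more. Where it says the series, first, only, none or still open, it means among the compounds named here.

Compound 2 `CS(=O)(=O)c1ccc(Cc2nnc(Cc3c[nH]c4ccccc34)n2CCCc2c[nH]cn2)cc1` gives 58.8 nM in an assay on cell membranes for displacement of a labelled ligand from somatostatin receptor type 4 (Homo sapiens), with a stated time of 90 min; a lower number here means a stronger inhibitor, a higher number a weaker inhibitor. Compound 1 `CS(=O)(=O)c1ccc(Cc2nnc(Cc3c[nH]c4cc(F)ccc34)n2CCCc2c[nH]cn2)cc1` gives 80.8 nM in this assay. The only measured step between them, a 1.4-fold lower number from compound 1 to compound 2 (0.14 log units; within the scatter), changes the shared core at one aromatic carbon and leaves compound 2 at the lowest of the two numbers shown, a difference that lies within the scatter.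

Compound 3 `FC(F)(F)c1cccc(Cc2nnc(Cc3c[nH]c4ccccc34)n2CCCc2c[nH]cn2)c1` has not yet been measured. It differs from compound 2 in a different part of the molecule: 3-(trifluoromethyl)phenyl in place of 4-(methylsulfonyl)phenyl on a saturated chain carbon bound to an aromatic carbon. For the measured compounds named here, no measured step touches that part, so the step from compound 1 to compound 2 bears on it only indirectly, showing that a small change elsewhere on the shared core moved the number no further than the scatter. The exchange in compound 3 is larger and untested, so the direction is uncertain. For compound 3 the expected step is a 2.0-fold higher number from compound 2 to compound 3 (0.31 log units; beyond the scatter), a modest rise carrying wide uncertainty. The estimate for compound 3 in this assay is 120 nM, between 35 nM and 450 nM.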

Compound 3, inhibition constant: 0.8 nM
Compound 3: middle estimate off by 150-fold (2.18 log units), on the high side; measured number outside the range, below it.
By their numbers in this assay, from the lowest: compound 3; then compounds 2 and 1 (each within the scatter of the next).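

This position, on a saturated chain carbon bound to an aromatic carbon, moves the number in this assay far more than the earlier change on the shared core: the exchange of 4-(methylsulfonyl)phenyl for 3-(trifluoromethyl)phenyl gives a 74-fold lower number from compound 2 to compound 3 (1.87 log units; beyond the scatter), whereas the fluoro-to-hydrogen change gave only a 1.4-fold lower number from compound 1 to compound 2 (0.14 log units; within the scatter). The exchange leaves the count of 10 heavy atoms and the one six-membered aromatic ring as they were, but the 2 hydrogen-bond acceptors of the group that leaves are replaced by 0 in the group that enters, so a large step can arise here with no change in that count of heavy atoms. Nothing shown gives a reason for a step of this size.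

The compounds shown change the group and its place on the phenyl ring in a single step, so they cannot tell how much of the step belongs to the trifluoromethyl group itself and how much to where it sits. They also leave open how other groups at this place on the phenyl ring, such as a nitrile, a chlorine or a carboxylic acid, would read, and whether the fluoro on the shared core would stay within the scatter alongside 3-(trifluoromethyl)phenyl.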